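The source may report more compounds than this note shows. Statements on the series, on what has been measured and on what is new or still open speak of the compounds shown alone.

Measured in a functional assay on BJAB cells (Homo sapiens) for antiproliferative activity, with a stated time of 4 days; a higher number here means that more compound is needed for the effect, a lower number that less compound is needed:
compound 1 `Cc1nn(-c2nc(-c3ccc(Cl)c(Cl)c3)c(SC(C)C)s2)c(C(=O)O)c1-c1cncnc1` gives 22000 nM;
compound 2 `Cc1ccccc1-c1c(C)nn(-c2nc(-c3ccc(Cl)c(Cl)c3)c(SC(C)C)s2)c1C(=O)O` gives 5500 nM;
compound 3 `Cc1nn(-c2nc(-c3ccc(Cl)c(Cl)c3)c(SC(C)C)s2)c(C(=O)O)c1-c1ccccc1[N+](=O)[O-]` gives 4700 nM.

Compound 2 stands second highest of the three numbers. Its nearest neighbour is compound 3, with a 1.2-fold lower number from compound 2 to compound 3 (0.07 log units; within the scatter), a step within the scatter; its furthest is compound 1, separated by a 4.0-fold lower number from compound 1 to compound 2 (0.60 log units; beyond the scatter). The account now follows the step from compound 2 to compound 4 `COc1cc(C#N)cc(-c2c(C)nn(-c3nc(-c4ccc(Cl)c(Cl)c4)c(SC(C)C)s3)c2C(=O)O)c1`, which has not yet been measured. The change is 3-cyano-5-methoxyphenyl in place of 2-methylphenyl on an aromatic carbon.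

Among the compounds with values here, no measured step exchanges one six-membered aromatic ring of carbon only for another carrying a nitrile and a methoxy group. Within the data shown here, the steps that bear on it are a 4.0-fold lower number from compound 1 to compound 2 (0.60 log units; beyond the scatter) and a 4.7-fold lower number from compound 1 to compound 3 (0.67 log units; beyond the scatter), both modest and beyond the scatter, and a 1.2-fold lower number from compound 2 to compound 3 (0.07 log units; within the scatter), within the scatter, which shows that changing the group on that ring from methyl to nitro altered little. A step no larger than the scatter is therefore expected for compound 4, namely a 1.2-fold lower number from compound 2 to compound 4 (0.09 log units; within the scatter). Compound 4 is estimated to give 4500 nM, within 1300 nM to 15000 nM.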

Compound 4, half-maximal effective concentration: 5200 nM
Estimate against measurement, compound 4: 1.2-fold (0.06 log units) below, within the range that was stated.
By their numbers in this assay, from the lowest: compounds 3, 4 and 2 (each within the scatter of the next); then compound 1.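

In this assay, the earlier compounds had shown only an exchange of methyl for nitro on the ring at this position; compound 4 brings in a larger 3-cyano-5-methoxyphenyl group with a nitrile and a methoxy group, yet a 1.1-fold lower number from compound 2 to compound 4 (0.02 log units; within the scatter) and a 1.1-fold higher number from compound 3 to compound 4 (0.04 log units; within the scatter) both stay within the scatter. The step of a 4.2-fold lower number from compound 1 to compound 4 (0.63 log units; beyond the scatter) is modest and beyond the scatter, so among these four compounds, the three with a ring of carbon only stand together and compound 1, with pyrimidin-5-yl, stands apart. No supporting measurement is available to explain this tolerance.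

The compounds shown leave open whether a plain phenyl ring would fall with this group. They also leave open whether a ring carrying an amine or a longer chain would stay with them or move towards compound 1.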